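A few compounds are considered here, and "the series" means these few. Any claim that something is new, unique, unknown or untested is made for them only; others in the source may bear on it.

Compound 1 `Cc1nc(C)n2c(S)nncc12`: in a functional assay for inhibition, with Homo sapiens as the target (a lower number here means a stronger inhibitor, a higher number a weaker inhibitor), compound 1 gives > 48000 nM, which is a limit of the assay rather than a number.
Compound 2 `CSc1nncc2c(C)nc(C)n12`: in this assay compound 2 gives > 48000 nM, again a limit.
Compound 3 `Cc1nc(C)n2c(O)nncc12`: in this assay compound 3 gives > 48000 nM, also a limit.

Compound 3 therefore stands where every measured compound stands, at the limit of > 48000 nM in this assay, at which 3 of the 3 values shown sit. From the compounds shown here alone, none of the three changes among them could be read: a step that the two limits leave unreadable from compound 1 to compound 2, a step that the two limits leave unreadable from compound 1 to compound 3 and a step that the two limits leave unreadable from compound 2 to compound 3 all run from one limit to another, so their size is unknown.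

Compound 4 `Cc1nc(C(C)C)n2c(O)nncc12` differs from compound 3 by isopropyl in place of methyl on an aromatic carbon. For the measured compounds named here, no measured step bears on this change, and nothing in the set shows a compound that was read as a number at all. The expectation is accordingly that compound 4 will most likely also return only a limit in this assay, with the step that the limit leaves unreadable from compound 3 to compound 4 from compound 3 to compound 4 expected to be no more than the usual scatter. The estimate for compound 4 is 100000 nM, between 30000 nM and 400000 nM.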

Compound 4, half-maximal inhibitory concentration: > 48000 nM
Compound 4 ended at the assay's limit; the forecaster's own chance of this, stated with the estimate: 85%; the middle value is on the limit's open side.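

The change from compound 3 to compound 4, isopropyl in place of methyl, cannot be read as a step of any size, since both compounds give only a limit in this assay: the limit of > 48000 nM in this assay, at which 4 of the 4 values shown sit. The compounds shown leave open whether any change to the shared core would give a readable number.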